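Shrinking the side chain of compound 1 to aminomethyl

This account rests on a few compounds, and the source may have more. Where it says the series, first, only, none or still open, it means among the compounds named here.

Compound 1 `NC(=O)[C@H](CO)Nc1cc(=O)oc2cc(OCc3cccc(Cl)c3)ccc12`: 2400 nM
Compound 2 `NC(=O)[C@@H]1CCCN1Cc1cc(=O)oc2cc(OCc3ccccc3)ccc12`: 380 nM
Compound 3 `CC(C(N)=O)c1cc(=O)oc2cc(OCc3ccccc3)ccc12`: 100 nM

In an assay for inhibition of Amine oxidase [flavin-containing] B (Rattus norvegicus) (on this read-out lower numbers stand for stronger inhibition and higher numbers for weaker inhibition), compound 1 gives the highest of the three numbers; compound 2 sits nearest, compound 3 furthest. Compound 4 `NCc1cc(=O)oc2cc(OCc3cccc(Cl)c3)ccc12` differs from compound 1 in one place: aminomethyl in place of (1-carbamoyl-2-hydroxyethyl)amino on an aromatic carbon. Within the data shown here, no measured step covers this exact exchange. The nearest guide is the move to a smaller group on the same position, a 3.8-fold lower number from compound 2 to compound 3 (0.58 log units; beyond the scatter), which lowered the number. Compound 4 also carries a smaller group, so a lower number is expected, of a size estimated as a 6.0-fold lower number from compound 1 to compound 4 (0.78 log units; beyond the scatter). The estimate for compound 4 in this assay is 400 nM, within a range from 100 nM to 1600 nM.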

Compound 4, half-maximal inhibitory concentration: 15 nM
Compound 4: middle estimate off by 27-fold (1.43 log units), on the high side, outside the stated range (below it).
By their numbers in this assay, from the lowest: compound 4; then compound 3; then compound 2; then compound 1.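

On this aromatic carbon, opposite the ring oxygen, trading the seven-heavy-atom (1-carbamoyl-2-hydroxyethyl)amino for aminomethyl gives a 160-fold lower number from compound 1 to compound 4 (2.20 log units; beyond the scatter) and a large step. This is a bigger change than the earlier 3.8-fold lower number from compound 2 to compound 3 (0.58 log units; beyond the scatter) and shows that, with the core of compound 1 kept, the group here can move the number very far. No evidence here explains the size of this drop. As far as these compounds go, it remains open which lost feature matters most: the hydroxyl, the amide, the stereocentre or the chain itself. From the compounds shown here alone, it is also open whether a longer chain such as aminoethyl, or a carboxylic acid, would keep the number this low.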